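Swapping Fluoro for Nitro: What Cytotoxicity to Expect

The source may hold more compounds than are shown below. What is called first, only, known or untested is meant among the compounds shown, and "the series" means these compounds.

Measured compounds:
Compound 1 `Cn1c(-c2ccccc2F)cnc1NC(=O)c1ccc(F)cc1` — in a toxicity assay on THP-1 cells (Homo sapiens) for inhibition (on this read-out lower numbers stand for higher toxicity in this test and higher numbers for lower toxicity in this test), compound 1 gives > 100000 nM, which is a limit of the assay rather than a number.
Compound 2 `Cn1c(-c2cccc(F)c2)cnc1NC(=O)c1ccc(F)cc1` — in this assay compound 2 gives 58000 nM.

Compound 1 therefore stands at the limit of this assay, as shown by the limit of > 100000 nM in this assay, at which 1 of the 2 values shown sits; only a bound is known for it, not a number. Among the compounds with values here, the single measured step, an at least 1.7-fold lower number from compound 1 to compound 2 (0.23 log units; that floor lies within the scatter), concerns a move of the fluoro group and lies within the scatter, so it offers little guidance for a different kind of change.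

Compound 3 `Cn1c(-c2ccccc2[N+](=O)[O-])cnc1NC(=O)c1ccc(F)cc1` differs from compound 1 by nitro in place of fluoro on an aromatic carbon. Within the data shown here, no measured step touches a nitro group, so nothing here points to a change beyond the scatter in either direction. The expectation is that compound 3 stays close to where compound 1 sits, which is expressed as an at least 1.1-fold lower number from compound 1 to compound 3 (0.04 log units; that floor lies within the scatter). Compound 3 is thus estimated in this assay at 90000 nM, with a range from 25000 nM to 300000 nM, and a real chance that only a limit is reported again.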

Compound 3, half-maximal cytotoxic concentration: 31000 nM
Estimate against measurement, compound 3: 2.9-fold (0.46 log units) above, and the stated range covers the measured number.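

Within the data shown here, this is the first change at this aromatic carbon that clears the scatter in this assay: nitro in place of fluoro gives an at least 3.2-fold lower number from compound 1 to compound 3 (0.50 log units; beyond the scatter), a shift towards higher toxicity in this test. The earlier step only moved the fluoro group and stayed within the scatter, so it could not show that the group at this carbon can matter; this step shows that it can. Compound 1 sits at a limit of the assay and not at a true number, so the step is only a floor and the real gap could be wider: the limit of > 100000 nM in this assay, at which 1 of the 3 values shown sits.

The compounds shown leave open which difference between the two groups counts, whether the larger number of heavy atoms, the hydrogen-bond acceptors that nitro brings, or something else. An amine or a nitrile on this same carbon would help to separate these possibilities, and nitro placed where compound 2 carries its fluoro would show whether the step depends on position.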